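The source may report more compounds than this note shows. Statements on the series, on what has been measured and on what is new or still open speak of the compounds shown alone.

Measured so far in an assay on blood for inhibition of C-X-C chemokine receptor type 3 (Homo sapiens), with a stated time of 30 min; on this read-out higher numbers stand for weaker inhibition and lower numbers for stronger inhibition:
Compound 1 `Cc1nc(-c2nc3ccccc3[nH]2)c(N2CCN(C(=O)Cn3cnc4cccnc43)[C@H](C)C2)s1` gives 1060 nM.
Compound 2 `Cc1nc(C)n(CC(=O)N2CCN(c3sc(C(F)(F)F)nc3-c3cnc(OC(C)C)nc3)C[C@H]2C)n1` gives 216 nM.

Within the data shown here, of the two compounds measured so far, compound 2 has the lower number in this assay, and the gap to compound 1 lies beyond the usual scatter of repeated measurements; no single-point comparison between these two is available, so only the two values themselves can be set side by side.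

Compound 3 `CCCc1ncc(-c2nc(C(F)(F)F)sc2N2CCN(C(=O)Cn3nc(C)nc3C)[C@H](C)C2)cn1` is not yet measured. It differs from compound 2 in one place: propyl in place of isopropoxy on an aromatic carbon. The change keeps the rest of the molecule intact and swaps one small group on the ring for another of similar size.

Because compound 2 reached 216 nM and the change is confined to a small group at the far end of the molecule, the step from compound 2 to compound 3 is expected to be modest, most likely within the scatter or a slight weakening: a 1.4-fold higher number from compound 2 to compound 3 (0.14 log units; within the scatter). For compound 3 the estimated value in this assay is 300 nM, with a likely range from 120 nM to 800 nM.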

Compound 3, half-maximal inhibitory concentration: 367 nM
Compound 3: middle estimate off by 1.2-fold (0.09 log units), on the low side, within the range that was stated.
By their numbers in this assay, from the lowest: compounds 2 and 3 (each within the scatter of the next); then compound 1.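

In this assay, replacing the 2-isopropoxypyrimidin-5-yl group with a 2-propylpyrimidin-5-yl group gives a 1.7-fold higher number from compound 2 to compound 3 (0.23 log units; within the scatter), so this read-out does not separate compound 2 from compound 3. Among these compounds, this pair gives the first direct look at a single change, here at the aromatic carbon between two ring nitrogen atoms: the isopropoxy group, with its oxygen and one hydrogen-bond acceptor, gives way to the propyl group, with no acceptor, and the step stays within the scatter. Nothing measured here offers a reason for this result.

Going by these compounds, with only these two groups seen at this carbon, it remains open whether an amine, a carboxylic acid or a longer chain such as hexyl would also leave the number within the scatter or move it beyond. Compound 1, at 1060 nM, differs from compound 2 and compound 3 in more than one place, so its value cannot show which of those differences matter in this assay for this receptor.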